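Pyridyl swap at the aryl terminus of the imidazole series

The source may hold more compounds than are shown below. What is called first, only, known or untested is meant among the compounds shown, and "the series" means these compounds.

Within the data shown here, compound 1 `CCC(C)(C)Cc1c[nH]c(CCc2ccc(-c3ccncc3)cc2)n1` gives 305 nM in a functional assay on HEK293 cells for agonist activity at Bombesin receptor subtype-3 (Homo sapiens), read by luminescence and calcium flux, with a stated time of 10 min (a higher number here means that more compound is needed for the effect, a lower number that less compound is needed), the lowest of the two numbers measured so far. Compound 2 `CCC(C)(C)Cc1c[nH]c(CCc2ccc(-c3csnn3)cc2)n1` gives 538 nM; the step of a 1.8-fold higher number from compound 1 to compound 2 (0.25 log units; within the scatter) shows that changing the ring at this position left the number essentially unchanged. Compound 3 `CCC(C)(C)Cc1c[nH]c(CCc2ccc(-c3cccnc3)cc2)n1` differs from compound 1 as follows: pyridin-3-yl in place of pyridin-4-yl on an aromatic carbon. Among the measured compounds shown here, the only relevant step, from compound 1 to compound 2, was within the scatter, so no step beyond the scatter is expected for compound 3 either. Compound 3 is therefore estimated at 400 nM (range 150 nM to 1100 nM), corresponding to an expected step of a 1.3-fold higher number from compound 1 to compound 3 (0.12 log units; within the scatter).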

Compound 3, half-maximal effective concentration: 131 nM
Compound 3: middle estimate off by 3.1-fold (0.48 log units), on the high side, outside the stated range (below it).
By their numbers in this assay, from the lowest: compound 3; then compounds 1 and 2 (each within the scatter of the next).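

Pyridin-3-yl in place of pyridin-4-yl gives a 2.3-fold lower number from compound 1 to compound 3 (0.37 log units; beyond the scatter) in this assay with the atoms and counted acceptors unchanged, so this position responds to the ring's attachment pattern and not only to ring identity. Pyridin-3-yl in place of 1,2,3-thiadiazol-4-yl gives a 4.1-fold lower number from compound 2 to compound 3 (0.61 log units; beyond the scatter) and separates two rings at this place by more than the scatter, which the first step could not do. Nothing available explains the difference.

Going by these compounds, whether pyridin-2-yl or an unsubstituted phenyl ring would extend this order remains open. Also open, on these data alone, is whether the pyridin-3-yl gain persists with a shorter chain in place of the branched alkyl group.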